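Compound 3 Takes (Pyrimidin-2-yl)amino in Place of 1H-Pyrazol-1-yl

This account rests on a few compounds, and the source may have more. Where it says the series, first, only, none or still open, it means among the compounds named here.

Of the compounds shown here, two have been measured in a functional assay for inhibition of sodium/hydrogen exchanger (Oryctolagus cuniculus); a lower number here means a stronger inhibitor, a higher number a weaker inhibitor. Compound 1 `Cc1cn(-c2cc(C)c(C(=O)N=C(N)N)cc2S(C)(=O)=O)cn1` gives 28 nM in this assay, and compound 2 `Cc1cc(-n2cccn2)c(S(C)(=O)=O)cc1C(=O)N=C(N)N` gives 25 nM. Among the measured compounds shown here, the single step between them, a 1.1-fold lower number from compound 1 to compound 2 (0.05 log units; within the scatter), consists of 1H-pyrazol-1-yl in place of 4-methyl-1H-imidazol-1-yl on an aromatic carbon. Compound 2 thus holds the lowest of the two numbers, but compound 1 sits within the scatter of it, so no order can be read from the pair.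

Compound 3 `Cc1cc(Nc2ncccn2)c(S(C)(=O)=O)cc1C(=O)N=C(N)N` has not yet been measured. It differs from compound 2 by (pyrimidin-2-yl)amino in place of 1H-pyrazol-1-yl on an aromatic carbon. For the measured compounds named here, the one measured step bears on this only loosely: it also exchanged the ring at this position and left the number essentially unchanged. Going by the values given here, the new change goes further, bringing in an amino link and a different ring, a kind of exchange no measured step covers, so the expectation rests on the small effect seen so far plus added uncertainty.

The step is expected to be modest, a 1.6-fold higher number from compound 2 to compound 3 (0.20 log units; within the scatter), somewhat more likely toward a higher number than a lower one. Compound 3 is therefore estimated at 40 nM in this assay, within a range from 10 nM to 160 nM.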

Compound 3, half-maximal inhibitory concentration: 8.3 nM
Estimate against measurement, compound 3: 4.8-fold (0.68 log units) above; the measured number lies below the stated range.
By their numbers in this assay, from the lowest: compound 3; then compounds 2 and 1 (each within the scatter of the next).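

In this assay, the aromatic carbon ortho to the methylsulfonyl group turns out to be a place where the number can move, since the ring exchange in a 1.1-fold lower number from compound 1 to compound 2 (0.05 log units; within the scatter) could not be told from scatter, whereas (pyrimidin-2-yl)amino in place of 1H-pyrazol-1-yl gives a 3.0-fold lower number from compound 2 to compound 3 (0.48 log units; beyond the scatter), and in place of 4-methyl-1H-imidazol-1-yl gives a 3.4-fold lower number from compound 1 to compound 3 (0.53 log units; beyond the scatter). The change to compound 3 brings in an amino link with one hydrogen-bond donor and also turns a five-membered aromatic ring into a six-membered one, so these compounds cannot separate the two parts of the change. Nothing measured here explains why the number falls with this group.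

On these data alone, whether a phenylamino group or a plain amine on this carbon would give a number like that of compound 3 remains open, and with it whether the link or the ring goes with the lower number. As far as these compounds go, the methyl and methylsulfonyl groups are the same in all three compounds, so it is also open whether this step would keep its size with an ethyl group in place of that methyl.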